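The source may report more compounds than this note shows. Statements on the series, on what has been measured and on what is new or still open speak of the compounds shown alone.

Compound 2 `O=C(O)CCCCCCCOc1ccc2c(=O)c(-c3ccc(O)cc3)coc2c1` is the reference point here. In an assay (Cricetulus griseus) for inhibition of aldehyde dehydrogenase, mitochondrial (Homo sapiens) (on this read-out lower numbers stand for stronger inhibition and higher numbers for weaker inhibition), compound 2 gives 40 nM, the lowest of the two numbers shown; compound 1 `O=C(O)CCCCCOc1ccc2c(=O)cc(-c3ccc(O)cc3)oc2c1` gives 3500 nM. Compound 3 `O=C(O)CCCCCCCCCCCCCCCOc1ccc2c(=O)c(-c3ccc(O)cc3)coc2c1` reaches only a limit of the assay, > 9000 nM, so that the limit of > 9000 nM in this assay, at which 1 of the 3 values shown sits, holds for it. For the measured compounds named here, the one step measured in one place, an at least 220-fold higher number from compound 2 to compound 3 (2.35 log units; beyond the scatter), shows how sharply lengthening the chain is punished. Compound 4 `CCOC(=O)CCCCCOc1ccc2c(=O)c(-c3ccc(O)cc3)coc2c1` carries a different change: ethoxycarbonyl in place of 2-carboxyethyl on a saturated chain carbon, five bonds along the chain from an oxygen on an aromatic ring. Going by the values given here, no measured step covers the loss of the acid, but the chain becomes shorter, and compound 1, with a shorter chain and a different arrangement of the core, sits far higher than compound 2. A weaker result is therefore expected for compound 4, with a 20-fold higher number from compound 2 to compound 4 (1.30 log units; beyond the scatter) as the expected step. Compound 4 is estimated at 800 nM, with a range from 150 nM to 5000 nM.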

Compound 4, half-maximal inhibitory concentration: 280 nM
For compound 4 the middle estimate is 2.9-fold (0.46 log units) above the measured one; low and high end bracket the measured number.
By their numbers in this assay, from the lowest: compound 2; then compound 4; then compound 1. At a limit, above all of these: compound 3.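

On a saturated chain carbon, five bonds along the chain from an oxygen on an aromatic ring, ethoxycarbonyl can replace 2-carboxyethyl and inhibition persists: this assay shows a 7.0-fold higher number from compound 2 to compound 4 (0.85 log units; beyond the scatter), a modest step. A free carboxylic acid at the chain end is therefore not required for activity on the shared core, though it accompanies the lowest number shown. Nothing shown accounts for this step. The compounds leave open whether the ester or the shorter chain drives the step, since a carboxylic acid on the chain of compound 4 and an ethyl ester on the chain of compound 2 are absent here. Going by these compounds, an amide or amine at the chain end also remains open.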